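A few compounds are considered here, and "the series" means these few. Any claim that something is new, unique, unknown or untested is made for them only; others in the source may bear on it.

Measured so far:
compound 1, `COc1cccc(-c2nc(SC)nc3sc(C(=O)NCC#N)c(N)c23)c1` — 20.3%
compound 2, `COc1cccc(-c2nc(SC)nc3sc(C(=O)NC(C)(C)C)c(N)c23)c1OC` — 50.1%

In a functional assay on HEK293 cells for agonist activity at lutropin-choriogonadotropic hormone receptor (Homo sapiens), read by cAMP accumulation (on this read-out lower numbers stand for smaller maximal responses and higher numbers for larger maximal responses), compound 1 stands lowest of the two numbers shown; compound 2 lies higher by a margin beyond the scatter. Compound 3, `COc1cccc(-c2nc(SC)nc3sc(C(=O)NNC(=O)OC(C)(C)C)c(N)c23)c1`, has not yet been tested. It differs from compound 1 by (tert-butoxycarbonyl)amino in place of cyanomethyl on an amide-type nitrogen, a larger group with one hydrogen-bond donor taking the place of the cyanomethyl on the amide-type nitrogen. Going by the values given here, no comparable step between measured compounds is available, so the direction rests only on the two numbers seen. A moderate rise is expected, a number 11.7 percentage points higher from compound 1 to compound 3 (beyond the scatter). Compound 3 is thus estimated at 32%, within 12% to 60%.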

Compound 3, largest response reached (reported as efficacy), in percent of the reference or control that the assay uses: 2.4%
For compound 3 the middle estimate is 29.6 percentage points above the measured one; measured number below the stated range.
By their numbers in this assay, from the lowest: compound 3; then compound 1; then compound 2.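

In this assay, (tert-butoxycarbonyl)amino in place of cyanomethyl on the amide-type nitrogen gives a number 17.9 percentage points lower from compound 1 to compound 3 (beyond the scatter). This single-place change shows that the response depends on the group carried at this nitrogen, and here the larger group goes with the smaller maximal response. The data shown offer no measured basis for explaining this fall. The compounds shown leave open whether the fall follows the whole tert-butoxycarbonyl unit or the added nitrogen alone. A simple amine or a longer alkyl chain in that place could separate the two.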